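The source may report more compounds than this note shows. Statements on the series, on what has been measured and on what is new or still open speak of the compounds shown alone.

Measured compounds:
Compound 1, `O=C(CCCCC1CCSS1)NCc1cn(CCCCOc2ccc3ccc(=O)oc3c2)nn1`, giving 52.8%
Compound 2, `O=C(CCCCC1CCSS1)NCc1cn(CCCCOc2ccc3cc(-c4ccccc4)c(=O)oc3c2)nn1`, giving 32.8%
Compound 3, `O=C(CCCCC1CCSS1)NCc1cn(CCCCOc2ccc3cc(-c4ccc(Br)cc4)c(=O)oc3c2)nn1`, giving 40.5%

In a functional assay on PC-12 cells (Rattus norvegicus) for cytotoxicity, read by MTT assay, with stated times of 3 h and 2 h, tested at 5 uM (a lower number here means a weaker effect, a higher number a stronger effect of the compound at the concentration tested), compound 3 stands second highest of the three numbers. Its nearest neighbour is compound 2, with a number 7.7 percentage points higher from compound 2 to compound 3 (within the scatter), a gap within the scatter; its furthest is compound 1, separated by a number 12.3 percentage points lower from compound 1 to compound 3 (beyond the scatter), beyond the scatter. Compound 4, `O=C(CCCCC1CCSS1)NCc1cn(CCCCOc2ccc3cc(-c4ccc(Cl)c(Cl)c4)c(=O)oc3c2)nn1`, has not yet been measured in this assay. It differs from compound 3 by 3,4-dichlorophenyl in place of 4-bromophenyl on an aromatic carbon.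

Two of the measured steps concern putting an aryl group in place of hydrogen on the shared core, namely a number 20 percentage points lower from compound 1 to compound 2 (beyond the scatter) and a number 12.3 percentage points lower from compound 1 to compound 3 (beyond the scatter); both are modest and lower the number. Within the data shown here, only one step changes the substitution on the phenyl ring itself, a number 7.7 percentage points higher from compound 2 to compound 3 (within the scatter), and it stays within the scatter. Among the measured compounds shown here, the change from compound 3 to compound 4 again alters only that phenyl ring, so no step beyond the scatter is expected in this assay. The expected step is a number 0.5 percentage points lower from compound 3 to compound 4 (within the scatter), within the scatter. Compound 4 is estimated to give 40%, with a range from 27% to 53%.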

Compound 4, a percentage reported as activity, at one concentration (the size of the read-out at that concentration, not a potency): 53.2%
Compound 4: middle estimate off by 13.2 percentage points, on the low side; the measured number lies above the stated range.
By their numbers in this assay, from the lowest: compounds 2 and 3 (each within the scatter of the next); then compounds 1 and 4 (each within the scatter of the next).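

In this assay, among these compounds, the aryl group on the shared core proves more sensitive to its substituents than the earlier compounds showed, since the change from 4-bromophenyl to 3,4-dichlorophenyl gives a step beyond the scatter, a number 12.7 percentage points higher from compound 3 to compound 4 (beyond the scatter), and the change from phenyl gives a number 20.4 percentage points higher from compound 2 to compound 4 (beyond the scatter). An aryl group in place of hydrogen at this position therefore does not always lower the number, as 3,4-dichlorophenyl gives a number 0.4 percentage points higher from compound 1 to compound 4 (within the scatter). Nothing measured here explains this difference between the two substituted phenyl groups.

It remains open whether the step depends on having two chlorines or on their particular arrangement, as a 4-chlorophenyl group does not stand among the compounds shown. Also open, as far as these compounds go, is how an aminophenyl or carboxyphenyl group at this position would read.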